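Dimethylpiperazinyl rearrangement in the sulfonyl series: compound 3

The compounds below may be only part of what the source reports. "The series", "measured", "known", "first", "only" and "open" are said of these compounds alone.

Measured compounds:
compound 1 `COc1cc2c(cc1N1C[C@@H](C)N[C@@H](C)C1)N(S(=O)(=O)c1ccc3ccccc3c1)CC2` — 1
compound 2 `COc1cc2c(cc1N1C[C@@H](C)N[C@@H](C)C1)N(S(=O)(=O)c1ccc(-c3ccccn3)s1)CC2` — 0.9

In a functional assay with growth hormone secretagogue receptor type 1 (Homo sapiens) as the target (a higher number here means a larger maximal response, a lower number a smaller maximal response), compound 1 gives 1 and compound 2 gives 0.9. For the measured compounds named here, the one measured step, a number 0.10 lower from compound 1 to compound 2 (within the scatter), leaves the two compounds within the scatter of each other, so compound 2 stands level with compound 1 on these numbers.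

Compound 3 `COc1cc2c(cc1N1CCNC(C)(C)C1)N(S(=O)(=O)c1ccc(-c3ccccn3)s1)CC2` differs from compound 2 by 3,3-dimethylpiperazin-1-yl in place of 3,5-dimethylpiperazin-1-yl on an aromatic carbon. No measured step touches this part of the molecule: the only step known concerns the group on the sulfonyl sulfur, and its size is given above. Guidance for the present change is therefore absent, and the expectation is that the step a number 0.050 lower from compound 2 to compound 3 (within the scatter) stays within the scatter, though a rearrangement of two methyl groups on the ring carrying the hydrogen-bond donor could move the maximal response either way. The estimate for compound 3 is 0.85, expected between 0.55 and 1.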

Compound 3, intrinsic activity: the largest response reached, as a fraction of the reference agonist's: 0.9
Beside the measured number, compound 3's estimate is 0.050 below it, and the stated range covers the measured number.
By their numbers in this assay, from the lowest: compounds 2, 3 and 1 (each within the scatter of the next).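

In this assay, for the compounds shown here, 3,3-dimethylpiperazin-1-yl in place of 3,5-dimethylpiperazin-1-yl on an aromatic carbon ortho to a methoxy group gives no change at the digits printed from compound 2 to compound 3 (within the scatter), the first reading at this position, since the earlier step concerned only the group on the sulfonyl sulfur. In this pair, the maximal response does not depend on the two defined stereocentres of 3,5-dimethylpiperazin-1-yl, as 3,3-dimethylpiperazin-1-yl has none. No supporting data bear on the origin of this result.

As far as these compounds go, the reading rests on one pair carrying 5-(pyridin-2-yl)thiophen-2-yl on the sulfonyl sulfur, so whether it holds with naphthalen-2-yl remains open. Also open, from the compounds shown here alone, is how this assay reads at this position with an unsubstituted piperazin-1-yl, a 4-methylpiperazin-1-yl or a morpholin-4-yl group.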